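This account rests on a few compounds, and the source may have more. Where it says the series, first, only, none or still open, it means among the compounds named here.

Measured compounds:
compound 1 `CNC(=O)c1cc(Oc2ccc(NC(=O)c3cc4cccnc4n(-c4ccccc4)c3=O)cc2)ccn1`: 250 nM
compound 2 `CNC(=O)c1cc(Oc2ccc(NC(=O)c3cc4cccnc4n(-c4ccc(F)cc4)c3=O)cc2)ccn1`: 160 nM

In a functional assay on HT-29 cells (Homo sapiens) for antiproliferative activity, read by MTT assay, with a stated time of 72 h (a higher number here means a weaker inhibitor, a lower number a stronger inhibitor), compound 1 gives 250 nM, the higher of the two numbers. Within the data shown here, its only neighbour is compound 2, which gives 160 nM in this assay, and the two values lie within the scatter of each other. Compound 3 `CNC(=O)c1cc(Oc2ccc(NC(=O)c3cc4cccnc4n(-c4ccc(Br)cc4)c3=O)cc2)ccn1` is the unmeasured member of the set; it differs from compound 1 by bromo in place of hydrogen on an aromatic carbon. Among the measured compounds shown here, the one measured step that bears on this change is a 1.6-fold lower number from compound 1 to compound 2 (0.19 log units; within the scatter), in which a fluoro entered at the same aromatic carbon. Since that step stayed within the scatter, a bromo at the same place is expected to move this assay little as well, perhaps to a somewhat lower number. Compound 3 is therefore estimated at 180 nM in this assay, with a range from 80 nM to 400 nM; this estimate corresponds to an expected step of a 1.4-fold lower number from compound 1 to compound 3 (0.14 log units; within the scatter).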

Compound 3, half-maximal inhibitory concentration: 1180 nM
Beside the measured number, compound 3's estimate is 6.6-fold (0.82 log units) below it, outside the stated range (above it).
By their numbers in this assay, from the lowest: compounds 2 and 1 (each within the scatter of the next); then compound 3.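

At this aromatic carbon, para to a large group, the change is not neutral for every substituent: in this assay going from phenyl to 4-bromophenyl gives a 4.7-fold higher number from compound 1 to compound 3 (0.67 log units; beyond the scatter) and so moves the number beyond the scatter, which the fluoro step had not shown. Bromo in place of fluoro at the same carbon gives a 7.4-fold higher number from compound 2 to compound 3 (0.87 log units; beyond the scatter) and shows that the two halogens are not interchangeable here, while hydrogen and fluoro remain within the scatter of each other. Nothing available accounts for the higher number with bromo.

Going by these compounds, whether a chloro or a methyl at this carbon would stay with hydrogen and fluoro or go with bromo remains open. So does how a methoxy, an amine or a carboxylic acid would fare at this same place.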